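The source may report more compounds than this note shows. Statements on the series, on what has been measured and on what is new or still open speak of the compounds shown alone.

Measured so far in an assay on isolated protein for inhibition of protein deacetylase HDAC6 (Homo sapiens), read by fluorescence, with a stated time of 1 h, tested at 100 nM; on this read-out higher numbers stand for more inhibition at the one concentration tested (going by the name of the read-out) and lower numbers for less inhibition:
compound 1 `COc1ccc(CN2CCC(c3noc(COc4ccc(/C=C/C(=O)NO)cc4)n3)CC2)cc1` — compound 1 gives 75%
compound 2 `CN(Cc1nc(C2CCN(Cc3ccccc3)CC2)no1)c1ncc(/C=C/C(=O)NO)cn1` — compound 2 gives 55%
compound 3 `CN(Cc1nc(C2CCN(Cc3ccccc3)CC2)no1)c1ncc(C(=O)NO)cn1` — compound 3 gives 63%

Compound 3 stands second of the three numbers. Its nearest neighbour is compound 2, and the step of a number 8 percentage points higher from compound 2 to compound 3 (within the scatter) lies within the scatter, so the two cannot be told apart on this read-out. Going by the values given here, compound 1 sits higher by a margin beyond the scatter, but no one-place step links compound 1 to compound 3, as the two differ in more than one place, so only the two values themselves can be set side by side.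

The next compound, compound 4 `CN(Cc1nc(C2CCN(Cc3ccc(C(F)(F)F)cc3)CC2)no1)c1ncc(C(=O)NO)cn1`, differs from compound 3 in one place:
trifluoromethyl in place of hydrogen on an aromatic carbon

Among the compounds with values here, no measured step bears on this change. Within the data shown here, the only step in hand, from compound 2 to compound 3, concerns the exchange of hydroxycarbamoyl for 2-(hydroxycarbamoyl)ethenyl and touches another part of the molecule, and compound 1 is separated from compound 3 by more than one change. Nothing in the series therefore points to a direction. The expected step of no change at the digits printed from compound 3 to compound 4 (within the scatter) is none beyond the scatter. Compound 4 is expected to give about 63%, with a range from 45% to 80%.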

Compound 4, a percentage reported as inhibition, at one concentration (the size of the read-out at that concentration, not a potency): 30%
Compound 4: middle estimate off by 33 percentage points, on the high side; measured number below the stated range.
By their numbers in this assay, from the lowest: compound 4; then compounds 2 and 3 (each within the scatter of the next); then compound 1.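

Notes on the benzyl end of the series: in this assay trifluoromethyl in place of hydrogen, on an aromatic carbon para to a large group, gives a number 33 percentage points lower from compound 3 to compound 4 (beyond the scatter) and is the only one-place step so far that clears the scatter. Going by these compounds alone, this position is therefore not a silent one: a change on the benzyl group, turning it into 4-(trifluoromethyl)benzyl, moves the read-out at the one concentration tested, whereas the hydroxycarbamoyl exchange between compound 2 and compound 3 gave no step that can be told from scatter. No measurement in hand accounts for this loss of inhibition, so the step stands as an observation on this one pair.

A single substituent cannot show whether the drop belongs to trifluoromethyl itself or to any group at this carbon, and a fluorine atom, a nitrile or an amine at the same place on the core of compound 3 would separate those readings. Also open, on these data alone, is whether trifluoromethyl on another carbon of the same ring, or on the core of compound 2, gives a step of similar size.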